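The source may hold more compounds than are shown below. What is called first, only, known or untested is meant among the compounds shown, and "the series" means these compounds.

Working notes on the series.

Among the compounds with values here, compound 1 `CSc1nc(-c2cccc(O)c2)c2c(N)c(C(=O)NC(C)(C)C)sc2n1` stands at the top of the two numbers so far: in a functional assay on HEK293 cells for agonist activity at lutropin-choriogonadotropic hormone receptor (Homo sapiens), read by cAMP accumulation (a lower number here means a smaller maximal response, a higher number a larger maximal response), compound 1 gives 63.9%. Compound 2 `CCOC(=O)c1sc2nc(SC)nc(-c3cccc(OC)c3)c2c1N` differs from compound 1 in more than one place. In this assay compound 2 gives only 4.2%, a gap beyond the usual scatter; no single-step comparison between these two exists, so the two values are stated as they stand.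

Compound 3 `COc1cccc(-c2nc(SC)nc3sc(C(=O)NC(C)(C)C)c(N)c23)c1F` is the next unmeasured member. Relative to compound 1 the change is 2-fluoro-3-methoxyphenyl in place of 3-hydroxyphenyl on an aromatic carbon.

Within the data shown here, no step between measured compounds is available, so the size of the move to compound 3 rests on compound 1 and compound 2 alone. The low value of compound 2, which also lacks the hydroxyl, weighs against a full retention of the response. The expected step is a drop beyond the scatter, a number 33.9 percentage points lower from compound 1 to compound 3 (beyond the scatter). For compound 3 in this assay the estimate is 30%, within 5% to 65%.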

Compound 3, largest response reached (reported as efficacy), in percent of the reference or control that the assay uses: 46.3%
The estimate for compound 3 lay 16.3 percentage points below the measured number, and the stated range covers the measured number.
By their numbers in this assay, from the lowest: compound 2; then compound 3; then compound 1.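

In this assay the exchange of 3-hydroxyphenyl for 2-fluoro-3-methoxyphenyl on this aromatic carbon can now be read directly: it gives a number 17.6 percentage points lower from compound 1 to compound 3 (beyond the scatter) and still leaves a clear response. Compound 3 stands at 46.3% with 0 hydrogen-bond donors on this group, so in the compounds shown a hydrogen-bond donor on this phenyl is not required for a sizeable maximal response. Nothing measured here bears on why the response falls with this change.

The step joins two changes, a methyl on the oxygen and an added fluorine, and the compounds shown do not separate them. As far as these compounds go, what a plain 3-methoxyphenyl would give here remains open, as does the effect of an amine or a carboxylic acid in place of the hydroxyl on this phenyl.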